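A few compounds are considered here, and "the series" means these few. Any claim that something is new, unique, unknown or untested is made for them only; others in the source may bear on it.

Compound 1 `c1ccc(-c2ccc(-c3ccc(-c4nc5ccccc5[nH]4)cc3)cc2)cc1`: 100000 nM
Compound 2 `Cc1ccc2[nH]c(-c3ccc(-c4ccc(-c5ccc(N(C)C)cc5)cc4)cc3)nc2c1`: 3230 nM
Compound 3 `COc1ccc(-c2ccc(-c3ccc(-c4nc5cc(C)ccc5[nH]4)cc3)cc2)cc1OC`: 1720 nM

All three numbers come from a functional assay on DWD cells (Homo sapiens) for inhibition, read by sulforhodamine B assay; on this read-out lower numbers stand for stronger inhibition of growth and higher numbers for weaker inhibition of growth. Compound 3 shares the low end of this small set with compound 2, and the two lie within the scatter of each other, while compound 1 sits far higher.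

Compound 4 `Cc1ccc2[nH]c(-c3ccc(-c4ccc(-c5ccccc5)cc4)cc3)nc2c1` follows from compound 3 by one change at the end of the molecule: phenyl in place of 3,4-dimethoxyphenyl (phenyl in place of 3,4-dimethoxyphenyl on an aromatic carbon).

For the measured compounds named here, only one measured step touches this position. In a 1.9-fold lower number from compound 2 to compound 3 (0.27 log units; within the scatter), one substituted end ring replaces another, and the number stays within the scatter. That step says little about a bare phenyl. The nearest hint is compound 1, which also ends in phenyl and gives 100000 nM, though its core is not the same as that of compound 4. A move towards weaker inhibition is therefore expected, with wide uncertainty, and the estimated step is a 3.5-fold higher number from compound 3 to compound 4 (0.54 log units; beyond the scatter).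

For compound 4 the expected value in this assay is 6000 nM, with an estimated range of 1800 nM to 40000 nM.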

Compound 4, concentration for 50% growth inhibition: 28300 nM
The estimate for compound 4 lay 4.7-fold (0.67 log units) below the measured number, and the stated range covers the measured number.
By their numbers in this assay, from the lowest: compounds 3 and 2 (each within the scatter of the next); then compound 4; then compound 1.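

In this assay, the step to a bare phenyl is far larger than the swap between the two substituted end rings: removing 3,4-dimethoxyphenyl gives a 16-fold higher number from compound 3 to compound 4 (1.22 log units; beyond the scatter), and removing dimethylamino gives an 8.8-fold higher number from compound 2 to compound 4 (0.94 log units; beyond the scatter), so within these compounds a substituent on the end ring goes with the lower numbers, whichever of the two it is. The end ring is not the only place that matters, as adding a methyl to the core with the phenyl end kept gives a 3.5-fold lower number from compound 1 to compound 4 (0.55 log units; beyond the scatter). Nothing shown here explains why either change has this effect.

For the compounds shown here, only two substituted end rings appear, so it remains open whether a single methoxy would match the 3,4-dimethoxyphenyl ring. A hydroxyl, a fluorine or a carboxylic acid at this place could also behave quite differently.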